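The source may hold more compounds than are shown below. What is called first, only, known or untested is meant among the compounds shown, and "the series" means these compounds.

Measured compounds:
compound 1, `Cc1nc2ccccc2c(=O)n1/N=C/c1ccc(Oc2ccc(Cl)cc2)cc1`: 4.6
compound 2, `CCCc1nc2ccccc2c(=O)n1/N=C/c1ccc(Oc2ccc(Br)cc2)cc1`: 5.88

In a physicochemical assay for lipophilicity, in phosphate buffer, measured as octanol-water partition (a higher number here means a more lipophilic compound, a lower number a more polar compound), compound 1 gives 4.6, the lower of the two numbers, while compound 2 gives 5.88, which lies higher by more than the scatter. For the measured compounds named here, no step between these two is given, so only their values stand side by side. Compound 3, `Cc1cc(Oc2ccc(/C=N/n3c(C)nc4ccccc4c3=O)cc2)ccc1Cl`, differs from compound 1 by methyl in place of hydrogen on an aromatic carbon, a methyl in place of hydrogen on an aromatic carbon, ortho to a chloro group. Such a change is expected to raise the partition coefficient by a modest amount, beyond the scatter. The expected step is a number 0.50 log units higher from compound 1 to compound 3 (beyond the scatter), upward. For compound 3 the estimate is 5.1, between 4.7 and 5.5.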

Compound 3, partition coefficient: 4.41
Estimate against measurement, compound 3: 0.69 log units above, and the stated range ends above it.
By their numbers in this assay, from the lowest: compounds 3 and 1 (each within the scatter of the next); then compound 2.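

In this assay, methyl in place of hydrogen on an aromatic carbon, ortho to a chloro group, gives a number 0.19 log units lower from compound 1 to compound 3 (within the scatter). For the compounds shown here, at this position of the 4-chlorophenoxy group, the added methyl therefore leaves no difference that can be told from the scatter, a single-place reading that the earlier compounds did not offer. Nothing available here bears on why this is so.

As far as these compounds go, whether an ethyl, a methoxy or an amine at this same place would also stay within the scatter remains open. So does whether methyl behaves alike at other positions of this ring.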